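Fluoro in place of methylsulfonyl on the shared core

This account rests on a few compounds, and the source may have more. Where it says the series, first, only, none or still open, it means among the compounds named here.

In a functional assay on HEp-2 cells (Homo sapiens) for cytotoxicity (on this read-out lower numbers stand for stronger inhibition and higher numbers for weaker inhibition), compound 1 (`CSc1nc(N)c2nnn(C3O[C@H](CO)[C@@H](O)[C@H]3O)c2n1`) gives > 130000 nM which is a limit and not a number (the limit of > 130000 nM in this assay, at which 1 of the 3 values shown sits). Compound 2 (`CS(=O)(=O)c1nc(N)c2nnn(C3O[C@H](CO)[C@@H](O)[C@H]3O)c2n1`) at 14000 nM holds the higher of the two true numbers, and compound 3 (`Nc1nc(N)c2nnn([C@@H]3O[C@H](CO)[C@@H](O)[C@H]3O)c2n1`) stands lower at 700 nM in this assay for now. Compound 4 (`Nc1nc(F)nc2c1nnn2C1O[C@H](CO)[C@@H](O)[C@H]1O`) carries fluoro in place of methylsulfonyl on an aromatic carbon between two ring nitrogen atoms (fluoro in place of methylsulfonyl on an aromatic carbon). For the measured compounds named here, the one measured step at this carbon (an at least 9.2-fold lower number from compound 1 to compound 2 (0.96 log units; beyond the scatter)) shows that the group there can move the read-out substantially. Going by the values given here, with compound 3 as the only lower number, a step of similar size towards a lower number is expected. The expected change is a 7.0-fold lower number from compound 2 to compound 4 (0.85 log units; beyond the scatter) in this assay on this reasoning. For compound 4 the estimate is 2000 nM with 150 nM to 20000 nM as the expected range.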

Compound 4, half-maximal inhibitory concentration: 2000 nM
Compound 4: the middle estimate sits on the measured number at the digits printed, and the stated range covers the measured number.
By their numbers in this assay, from the lowest: compound 3; then compound 4; then compound 2. At a limit, above all of these: compound 1.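

In this assay, the step of a 7.0-fold lower number from compound 2 to compound 4 (0.85 log units; beyond the scatter) shows that methylsulfonyl does not give the lowest number among the groups on this aromatic carbon, and that the smaller fluoro gives a lower one. Compound 1 stands at a limit and not a number: the limit of > 130000 nM in this assay, at which 1 of the 4 values shown sits. Read from that limit, the span on this carbon is an at least 65-fold lower number from compound 1 to compound 4 (1.81 log units; beyond the scatter), so methylsulfanyl, methylsulfonyl and fluoro fall in descending order of read-out.

Still open, on these data alone, is where chloro or methoxy on this carbon would fall in that order. Also open, as far as these compounds go, is whether the order holds with changes elsewhere on the shared core.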